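A Methoxyphenyl Ester on a Glycoside Scaffold

The source may report more compounds than this note shows. Statements on the series, on what has been measured and on what is new or still open speak of the compounds shown alone.

Compound 2 `C/C=C1/[C@H](O[C@@H]2O[C@H](CO)[C@@H](O)[C@H](O)[C@H]2O)OC=C(C(=O)OC)[C@H]1CC(=O)OCC`: > 15000 nM
Compound 1 `C/C=C1/[C@H](O[C@@H]2O[C@H](CO)[C@@H](O)[C@H](O)[C@H]2O)OC=C(C(=O)OC)[C@H]1CC(=O)OCCc1ccc2c(c1)OCCO2`: > 20000 nM

Neither value shown is a number. In a functional assay on SK-BR-3 cells (Homo sapiens) for antiproliferative activity, read by MTT assay, with a stated time of 72 h (on this read-out lower numbers stand for stronger inhibition and higher numbers for weaker inhibition), compound 2 gives > 15000 nM, which is a limit of the assay. In this assay compound 1 gives > 20000 nM, likewise a limit. Within the data shown here, the one change between them, a step that the two limits leave unreadable from compound 1 to compound 2, has no readable size: compound 1 sits at the limit of > 20000 nM in this assay, at which 1 of the 2 values shown sits, and compound 2 at the limit of > 15000 nM in this assay, at which 1 of the 2 values shown sits, so nothing can be said about whether the aryl group at that position helps or harms.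

Compound 3 `C/C=C1/[C@H](O[C@@H]2O[C@H](CO)[C@@H](O)[C@H](O)[C@H]2O)OC=C(C(=O)OC)[C@H]1CC(=O)OCCc1ccc(OC)cc1` differs from compound 2 by 4-methoxyphenyl in place of hydrogen on a saturated chain carbon, two bonds along the chain from an oxygen next to a carbonyl group. Among the measured compounds shown here, the only measured step at this position is the unreadable one just described, so there is no evidence that any substituent on this chain carbon brings potency inside the measurable window. Compound 3 is therefore expected to behave like compound 2, and the step that the limit leaves unreadable from compound 2 to compound 3 is estimated to stay within the scatter, with the assay most likely reporting a limit again. Compound 3 is estimated at 30000 nM in this assay, with a range from 10000 nM to 100000 nM.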

Compound 3, half-maximal inhibitory concentration: > 20000 nM
Compound 3 gave a limit, no number (the forecaster's own chance of this, stated with the estimate: 80%); the middle value does not contradict the limit.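

In this assay compound 3 gives > 20000 nM as a limit of the assay, not a number. Among these compounds, with compound 1, compound 2 and compound 3 all standing at limits, no step among them can be read. The compounds shown leave open whether in this assay any group on this chain carbon gives a measurable value at all.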